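Replacing benzyl with phenyl in compound 2

This account rests on a few compounds, and the source may have more. Where it says the series, first, only, none or still open, it means among the compounds named here.

Measured in a functional assay on KB cells (Homo sapiens) for cytotoxicity; on this read-out higher numbers stand for an effect only at larger amounts of compound and lower numbers for an effect already at smaller amounts:
compound 1 `CCN(Cc1cnc2nc(N)nc(N)c2n1)c1ccc(C(=O)N[C@@H](CCC(=O)O)C(=O)O)cc1`: 0.005 ug/mL
compound 2 `Nc1nc(N)c2nc(CN(Cc3ccccc3)c3ccc(C(=O)N[C@@H](CCC(=O)O)C(=O)O)cc3)cnc2n1`: > 100 ug/mL (a limit)

Compound 2 gives > 100 ug/mL in this assay, which is a limit and not a number. Compound 3 `Nc1nc(N)c2nc(CN(c3ccccc3)c3ccc(C(=O)N[C@@H](CCC(=O)O)C(=O)O)cc3)cnc2n1` has phenyl in place of benzyl on a nitrogen on an aromatic ring. Within the data shown here, only one measured step bears on this change: an at least 20000-fold higher number from compound 1 to compound 2 (4.30 log units; beyond the scatter). That step is large and beyond the scatter, and it came with phenyl in place of methyl on a saturated chain carbon bound to a nitrogen on an aromatic ring. Compound 3 keeps one six-membered aromatic ring of carbon only in this region, as compound 2 does, so it is expected to lie far closer to compound 2 than to compound 1. Any expected shift is small and toward a lower number. The expected step is an at least 2.0-fold lower number from compound 2 to compound 3 (0.30 log units; that floor lies within the scatter). For compound 3 the estimate is 50 ug/mL, with an expected range of 5 ug/mL to 200 ug/mL.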

Compound 3, concentration for half-maximal effect: 26 ug/mL
Compound 3: middle estimate off by 1.9-fold (0.28 log units), on the high side, and the stated range covers the measured number.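

Compound 3 supplies the first actual number in this assay for a six-membered aromatic ring of carbon only carried on this nitrogen, as compound 2 is known only through a limit: the limit of > 100 ug/mL in this assay, at which 1 of the 3 values shown sits.

Phenyl in place of benzyl brings an at least 3.8-fold lower number from compound 2 to compound 3 (0.58 log units; beyond the scatter), so this change is beyond the scatter, although its full size cannot be read from a limit. Even so, phenyl in place of ethyl still gives a 5200-fold higher number from compound 1 to compound 3 (3.72 log units; beyond the scatter), which means that in both compounds bearing such a ring, compound 2 and compound 3, the number stays far from that of compound 1.

Going by these compounds, whether a propyl chain, a hydroxyethyl chain or an aminoethyl chain on this nitrogen would stay close to compound 1 remains open. So does the effect of a fluorine or a methoxy group on the phenyl ring of compound 3.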